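A few compounds are considered here, and "the series" means these few. Any claim that something is new, unique, unknown or untested is made for them only; others in the source may bear on it.

Working notes on the series. The shared core carries a benzylamine whose aryl substitution varies. Compound 1 `Nc1cc(N)c2nc(-c3ccccc3)c(NCc3ccc(Cl)c(Cl)c3)nc2c1` gives 69200 nM in a functional assay on OVCAR-5 cells (Homo sapiens) for inhibition, read by sulforhodamine B assay, with a stated time of 48 h; on this read-out lower numbers stand for higher toxicity in this test and higher numbers for lower toxicity in this test. Compound 2 `COc1ccc(CNc2nc3cc(N)cc(N)c3nc2-c2ccccc2)cc1OC` gives 81300 nM in this assay, and the step of a 1.2-fold higher number from compound 1 to compound 2 (0.07 log units; within the scatter) is within the scatter. Compound 3 `Nc1cc(N)c2nc(-c3ccccc3)c(NCc3ccc(F)cc3)nc2c1` stands at a limit, < 100000 nM, not a number. The steps a step that the limit leaves unreadable from compound 1 to compound 3 and a step that the limit leaves unreadable from compound 2 to compound 3 are therefore unreadable, because of the limit (the limit of < 100000 nM in this assay, at which 1 of the 3 values shown sits).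

Compound 4 `COc1ccc(CNc2nc3cc(N)cc(N)c3nc2-c2ccccc2)cc1` is not yet measured. From compound 3 it differs by methoxy in place of fluoro on an aromatic carbon. Among the measured steps only the one from compound 1 to compound 2, which swapped halogens for methoxy groups, bears on this change, and it lay within the scatter; the steps into compound 3 give no readable size. No step beyond the scatter is therefore expected in this assay, and compound 4 is expected to fall near compound 1 and compound 2, with the step that the limit leaves unreadable from compound 3 to compound 4 unreadable against the limit of compound 3. The estimate for compound 4 is 80000 nM, between 40000 nM and 160000 nM.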

Compound 4, concentration lethal to 50% of the cells: < 100000 nM
Compound 4 ended at the assay's limit (the forecaster's own chance of this, stated with the estimate: 40%); the middle value lies beyond the limit too.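

No new step can be read from compound 4 to compound 1, compound 2 or compound 3 in this assay, because compound 3 and compound 4 each stand at a limit: the limit of < 100000 nM in this assay, at which 2 of the 4 values shown sit.

The compounds shown leave open whether 4-fluorobenzyl and 4-methoxybenzyl differ on this read-out at all.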